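Ring size at the ester oxygen: cycloheptyl to cyclohexyl

The source may hold more compounds than are shown below. What is called first, only, known or untested is meant among the compounds shown, and "the series" means these compounds.

Measured compounds:
compound 1 `COc1ccc(COC(=O)[C@H](CC(=O)OC2CCCCCC2)NC(=O)OC(C)(C)C)cc1` — 2600 nM
compound 2 `COc1ccc(CN(C)C(=O)[C@H](COCC2CCCCC2)NC(=O)OC(C)(C)C)cc1` — 1800 nM

Both measured compounds were read in a functional assay on IMR-32 cells for inhibition of Voltage-dependent N-type calcium channel subunit alpha-1B (Homo sapiens), read by calcium flux; on this read-out lower numbers stand for stronger inhibition and higher numbers for weaker inhibition. In this assay compound 1 gives 2600 nM. In this assay compound 2 gives 1800 nM. Compound 1 holds the higher of the two numbers, but its gap to compound 2 lies within the scatter, so the two cannot be ordered. Among the measured compounds shown here, no pair of measured compounds differs in a single place, so no measured step is available.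

Compound 3 `COc1ccc(COC(=O)[C@H](CC(=O)OC2CCCCC2)NC(=O)OC(C)(C)C)cc1` differs from compound 1 by cyclohexyl in place of cycloheptyl on an oxygen next to a carbonyl group. Everything else in the structure is kept. For the measured compounds named here, nothing among the measured compounds shows what this exchange does, and the change is small. Compound 3 is therefore expected close to compound 1, at an estimated 2600 nM, with a range of 1000 nM to 7000 nM. The step of no change at the digits printed from compound 1 to compound 3 (within the scatter) is expected to stay within the scatter, with no clear direction.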

Compound 3, half-maximal inhibitory concentration: 2300 nM
Compound 3: middle estimate off by 1.1-fold (0.05 log units), on the high side; the measured number falls inside the stated range.
By their numbers in this assay, from the lowest: compounds 2, 3 and 1 (each within the scatter of the next).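

In this assay, among the compounds shown here, cyclohexyl in place of cycloheptyl on an oxygen next to a carbonyl group gives a 1.1-fold lower number from compound 1 to compound 3 (0.05 log units; within the scatter), the first measured step that differs in one place. At this position, these two carbon-only rings therefore cannot be told apart on this read-out. No supporting measurement bears on this result.

From the compounds shown here alone, whether an open chain such as n-hexyl, or a ring carrying an amine or a carboxylic acid, would shift the number beyond the scatter at this position remains open. Compound 2 differs from compound 1 and compound 3 in more than one place, so what its different linkages contribute also remains unresolved.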